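The source may hold more compounds than are shown below. What is called first, only, known or untested is meant among the compounds shown, and "the series" means these compounds.

Measured so far in an in vitro ADME assay on microsomes from liver (Homo sapiens) for metabolic stability, tested at 1 uM; a higher number here means that the compound lasts longer, a lower number that the compound disappears faster:

compound 1 `CC(C)CCN1C(=O)C(C2=NS(=O)(=O)c3cc(NS(C)(=O)=O)ccc3N2)=C(O)[C@@H]2[C@H]3CC[C@H](C3)[C@@H]21` gives 0.617 h
compound 2 `CS(=O)(=O)Nc1ccc2c(c1)S(=O)(=O)N=C(C1=C(O)[C@@H]3[C@H]4CC[C@H](C4)[C@@H]3N(CC3CCCCC3)C1=O)N2` gives 0.733 h
compound 3 `CC(C)CCN1C(=O)C(C2=NS(=O)(=O)c3cc(NS(C)(=O)=O)ccc3N2)=C(O)[C@@H]2[C@@H]3CC[C@@H](C3)[C@@H]21` gives 0.3 h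

Within this core, the change cyclohexyl in place of isobutyl on a saturated chain carbon bound to an amide-type nitrogen in a ring produced a 1.2-fold higher number from compound 1 to compound 2 (0.07 log units; within the scatter), so the two values sit together. The two cores differ as the two compounds have the same atoms and bonds and differ only in configuration as drawn: 2 of 4 stereo elements differ; a stereocentre at a saturated ring carbon is drawn S in compound 1 and R in compound 3; a stereocentre at a saturated ring carbon is drawn R in compound 1 and S in compound 3; this step, a 2.1-fold lower number from compound 1 to compound 3 (0.31 log units; beyond the scatter), stands out modestly, and it can be set against nothing but configuration because of the fact that compounds 1 and 3 differ only in the configuration as drawn. Compound 3 holds the lowest number of the three, with both others beyond the scatter from it.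

Compound 4 `CS(=O)(=O)Nc1ccc2c(c1)S(=O)(=O)N=C(C1=C(O)[C@@H]3[C@@H]4CC[C@@H](C4)[C@@H]3N(CC3CCCCC3)C1=O)N2` applies the same kind of change on the core of compound 3: cyclohexyl in place of isobutyl on a saturated chain carbon bound to an amide-type nitrogen in a ring, the place being the same in both cases. In this assay the step from compound 3 to compound 4 is expected to be a 1.2-fold higher number from compound 3 to compound 4 (0.07 log units; within the scatter). That expectation rests on the earlier step, a 1.2-fold higher number from compound 1 to compound 2 (0.07 log units; within the scatter), which stayed within the scatter. Compound 4 is therefore estimated at 0.35 h, with a likely range from 0.18 h to 0.7 h.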

Compound 4, half-life: 0.25 h
The estimate for compound 4 lay 1.4-fold (0.15 log units) above the measured number, and the stated range covers the measured number.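

In this assay, cyclohexyl in place of isobutyl gives a 1.2-fold lower number from compound 3 to compound 4 (0.08 log units; within the scatter), and the change carries from one core to the other with no difference that can be told apart: the same change on two cores in this assay, a 1.2-fold higher number (0.07 log units; within the scatter) from compound 1 to compound 2 and a 1.2-fold lower number (0.08 log units; within the scatter) from compound 3 to compound 4, 1.4-fold (0.15 log units) apart, within the scatter of two such steps. This shows that on these two cores the change leaves the half-life within the scatter; it does not show that the same would hold on any further core, and two pairs give no direction for the change. The configuration step, by contrast, stays beyond the scatter with cyclohexyl as well, at a 2.9-fold lower number from compound 2 to compound 4 (0.47 log units; beyond the scatter), alongside a 2.1-fold lower number from compound 1 to compound 3 (0.31 log units; beyond the scatter) with isobutyl: the fact that compounds 2 and 4 differ only in the configuration as drawn.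

Open, on these data alone, is whether a group of another kind at this place, such as an amine, a carboxylic acid or a longer chain, would behave the same way. Also open, as far as these compounds go, is whether the gap between the two configurations would persist with such groups.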